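The source may hold more compounds than are shown below. What is called first, only, known or untested is meant among the compounds shown, and "the series" means these compounds.

Values so far in a functional assay on MCF7 cells (Homo sapiens) for cytotoxicity, read by MTT assay, with a stated time of 72 h; on this read-out lower numbers stand for stronger inhibition and higher numbers for weaker inhibition:
- compound 1 `CNC(=O)c1cc(Oc2ccc(C3CC(c4ccc([N+](=O)[O-])cc4)=NN3)cc2)ccn1` at 8030 nM
- compound 2 `CNC(=O)c1cc(Oc2ccc(C3CC(c4ccc(Br)cc4)=NN3)cc2)ccn1` at 15300 nM
- compound 3 `CNC(=O)c1cc(Oc2ccc(C3CC(c4ccc(Cl)cc4)=NN3)cc2)ccn1` not yet measured

Going by the values given here, compound 2 stands at 15300 nM and compound 1 at 8030 nM on the numbers so far, which puts the two within the scatter of each other, so they cannot be ranked. Compound 3 differs from compound 2 by chloro in place of bromo on an aromatic carbon at the site para to a large group, a change from 4-bromophenyl to 4-chlorophenyl. Among the compounds with values here, one measured step bears on this site: bromo in place of nitro gave a 1.9-fold higher number from compound 1 to compound 2 (0.28 log units; within the scatter) and so did not leave the scatter. Within the data shown here, no compound with chloro has been measured yet, so this single step is all the evidence available. On that basis no step beyond the scatter is expected in this assay for this change. The expected step is a 1.2-fold lower number from compound 2 to compound 3 (0.07 log units; within the scatter) and it stays inside the scatter. Compound 3 is estimated at 13000 nM with an expected range of 6000 nM to 27000 nM in this assay for now.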

Compound 3, half-maximal inhibitory concentration: 15300 nM
For compound 3 the middle estimate is 1.2-fold (0.07 log units) below the measured one; measured number inside the range.
By their numbers in this assay, from the lowest: compounds 1, 2 and 3 (each within the scatter of the next).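

Notes on the site para to a large group, read in this assay: chloro in place of bromo gives no change at the digits printed from compound 2 to compound 3 (within the scatter) and adds a second halogen to the comparison. Chloro in place of nitro gives a 1.9-fold higher number from compound 1 to compound 3 (0.28 log units; within the scatter) and is the same size as the bromo replacement of nitro (a 1.9-fold higher number from compound 1 to compound 2 (0.28 log units; within the scatter)), so none of the three steps among nitro, bromo and chloro leaves the scatter and these three groups cannot be ranked at this site. No measurement available here explains this result or links it to any property of these groups.

As far as these compounds go, whether an amine, a carboxylic acid or a methoxy group at this site, or a bare phenyl with hydrogen in place of the halogen, would move the number in this assay beyond the scatter remains open. The methyl on the amide of the shared core is also the same in all three compounds, which leaves open whether a longer chain there would matter more than the changes seen at this site.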